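Notes on lengthening the chain of compound 1

The compounds below may be only part of what the source reports. "The series", "measured", "known", "first", "only" and "open" are said of these compounds alone.

Values in a functional assay on MDA-MB-231 cells (Homo sapiens) for antiproliferative activity, read by MTT assay, with a stated time of 48 h (a lower number here means a stronger inhibitor, a higher number a weaker inhibitor), stand as follows:
- compound 1 `O=C(CCCCCC(=O)Nc1nnc(-c2ccncc2)s1)NO`: 40100 nM
- compound 2 `O=C(CCCCCC(=O)Nc1nnc(-c2cccs2)s1)NO`: 15200 nM
- compound 3 `O=C(CCCCCC(=O)Nc1nnc(-c2cccnc2)s1)NO`: 11700 nM

Compound 1 has the highest of the three numbers, and both steps from it lie beyond the scatter. Compound 4 `O=C(CCCCCCC(=O)Nc1nnc(-c2ccncc2)s1)NO` differs from compound 1 by (hydroxycarbamoyl)methyl in place of hydroxycarbamoyl on a saturated chain carbon, five bonds along the chain from a carbonyl carbon. Within the data shown here, no measured step touches the chain. Only the changes on the aromatic carbon give a scale: a 2.6-fold lower number from compound 1 to compound 2 (0.42 log units; beyond the scatter) and a 3.4-fold lower number from compound 1 to compound 3 (0.53 log units; beyond the scatter) were modest, while a 1.3-fold lower number from compound 2 to compound 3 (0.11 log units; within the scatter) stays within the scatter. With compound 1 at 40100 nM as the top of the range, a similarly modest step toward a lower number is tentatively expected. The expected step is a 2.0-fold lower number from compound 1 to compound 4 (0.30 log units; within the scatter) as a rough estimate. For compound 4 the estimate is 20000 nM with an expected range from 6000 nM to 60000 nM as working figures.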

Compound 4, half-maximal inhibitory concentration: 4690 nM
Compound 4: middle estimate off by 4.3-fold (0.63 log units), on the high side; measured number outside the range, below it.
By their numbers in this assay, from the lowest: compound 4; then compounds 3 and 2 (each within the scatter of the next); then compound 1.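

In this assay, the saturated chain is a responsive position: (hydroxycarbamoyl)methyl in place of hydroxycarbamoyl gives a larger step (an 8.6-fold lower number from compound 1 to compound 4 (0.93 log units; beyond the scatter)) than the best change on the aromatic carbon (a 3.4-fold lower number from compound 1 to compound 3 (0.53 log units; beyond the scatter)). On compound 1, then, this change to the chain moves the number further than either aromatic exchange shown. No evidence at hand accounts for the step.

Still open, as far as these compounds go, is whether a longer chain than that of compound 4 lowers the number further or reverses the gain. Also open, from the compounds shown here alone, is whether the same change carries over to the thiophen-2-yl and pyridin-3-yl members, compound 2 and compound 3.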